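A few compounds are considered here, and "the series" means these few. Any claim that something is new, unique, unknown or untested is made for them only; others in the source may bear on it.

Measured compounds in an assay on isolated protein for inhibition of DNA topoisomerase 1 (Homo sapiens), with a stated time of 30 min, tested at 100 uM; a lower number here means a weaker effect, a higher number a stronger effect of the compound at the concentration tested:

compound 1, `Oc1ccc(-c2cc(-c3ccc(Cl)cc3)nc(-c3cccnc3)c2)cc1`, gives 18.8%
compound 2, `Oc1cccc(-c2cc(-c3cccnc3)nc(-c3ccccc3Cl)c2)c1`, gives 0%
compound 3, `Oc1cccc(-c2cc(-c3ccc(Cl)cc3)nc(-c3cccnc3)c2)c1`, gives 2.8%

Compound 3 stands second highest of the three numbers. Its nearest neighbour is compound 2: the step of a number 2.8 percentage points higher from compound 2 to compound 3 (within the scatter) lies within the scatter, so the two cannot be ordered. Its furthest is compound 1: the step of a number 16 percentage points lower from compound 1 to compound 3 (beyond the scatter) is beyond the scatter and modest in size.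

Compound 4, `Oc1cccc(-c2cc(-c3ccc(Cl)cc3)nc(-c3ccco3)c2)c1`, is not yet measured. It differs from compound 3 in one place: furan-2-yl in place of pyridin-3-yl on an aromatic carbon.

Neither measured step bears directly on this change. The step from compound 1 to compound 3 alters the hydroxyphenyl group, the step from compound 2 to compound 3 alters the chlorophenyl group; the group on the aromatic carbon next to the ring nitrogen is the same in all three measured compounds. Within the data shown here, there is thus no measured precedent for swapping pyridin-3-yl for furan-2-yl at this carbon. In the absence of such a precedent, and with compound 3 already low in this assay, the step of a number 1.2 percentage points higher from compound 3 to compound 4 (within the scatter) is expected to stay within the scatter. Compound 4 is therefore estimated at 4% in this assay, with a range from 0% to 14%.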

Compound 4, a percentage reported as inhibition, at one concentration (the size of the read-out at that concentration, not a potency): 27.1%
The estimate for compound 4 lay 23.1 percentage points below the measured number, outside the stated range (above it).
By their numbers in this assay, from the lowest: compounds 2 and 3 (each within the scatter of the next); then compounds 1 and 4 (each within the scatter of the next).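

In this assay, among these compounds, the step of a number 24.3 percentage points higher from compound 3 to compound 4 (beyond the scatter) shows that the group on the aromatic carbon next to the ring nitrogen can change the read-out by more than the scatter, which the earlier compounds could not show because they all carry pyridin-3-yl there. The change replaces a six-membered aromatic ring containing nitrogen with a five-membered aromatic ring containing oxygen, while the counts of hydrogen-bond donors and acceptors stay the same, so those counts do not distinguish the two groups. No measurement shown here explains why the furan-2-yl compound gives the higher number.

Ring size and the identity of the hetero atom remain confounded, and it is open whether thiophen-2-yl, furan-3-yl or plain phenyl at this carbon would read like compound 3 or like compound 4. Also open, from the compounds shown here alone, is whether furan-2-yl would produce a similar step alongside the 4-hydroxyphenyl group of compound 1 or the 2-chlorophenyl group of compound 2, and whether the difference would hold at other concentrations, since this read-out comes from a single concentration and is not a potency.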